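The compounds below may be only part of what the source reports. "The series", "measured", "known", "first", "only" and "open" are said of these compounds alone.

Four close relatives of one scaffold were examined for their effect on the growth of cancer cells. Compound 1 `N=C(N)N/N=C/c1c(-c2ccsc2)nc2sccn12` carries a thiophen-3-yl group on an aromatic carbon of its shared core. In a functional assay on cells (Cancer cell lines, Homo sapiens) for inhibition (on this read-out lower numbers stand for stronger inhibition of growth and higher numbers for weaker inhibition of growth), compound 1 gives 14100 nM. Compound 2 `Cc1cc(-c2nc3sccn3c2/C=N/NC(=N)N)c(C)s1` differs from it in one place only, (2,5-dimethylthiophen-3-yl in place of thiophen-3-yl on an aromatic carbon), and in this assay compound 2 gives 15500 nM. That single change produced a 1.1-fold higher number from compound 1 to compound 2 (0.04 log units; within the scatter), so the two values cannot be told apart by this measurement.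

Compound 3 `N=C(N)N/N=C/c1c(-c2ccsc2)nc2n1CCS2` shares the same thiophen-3-yl group but sits on a different core; how the two cores differ is not broken down here. In this assay compound 3 gives 22900 nM, a number that lies within the usual scatter of both compound 1 and compound 2.

Compound 4 `Cc1cc(-c2nc3n(c2/C=N/NC(=N)N)CCS3)c(C)s1` has not yet been measured. It is made from compound 3 by 2,5-dimethylthiophen-3-yl in place of thiophen-3-yl on an aromatic carbon. Going by the values given here, this is the same kind of change as the one from compound 1 to compound 2; the surroundings of the place differ in that, in compound 3 and compound 4, it is also two ring bonds from two ring atoms that each bear a fused ring. Because a 1.1-fold higher number from compound 1 to compound 2 (0.04 log units; within the scatter) was within the scatter, the step from compound 3 to compound 4 is expected to be equally small, about a 1.1-fold higher number from compound 3 to compound 4 (0.04 log units; within the scatter). On that basis compound 4 is estimated to give 25000 nM in this assay, with a likely range from 12000 nM to 50000 nM.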

Compound 4, concentration for 50% growth inhibition: 13800 nM
Estimate against measurement, compound 4: 1.8-fold (0.26 log units) above, within the range that was stated.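

In this assay, putting 2,5-dimethylthiophen-3-yl in place of thiophen-3-yl on the core of compound 3 produced a 1.7-fold lower number from compound 3 to compound 4 (0.22 log units; within the scatter), so this measurement cannot tell these two compounds apart. Set beside the earlier step, the change behaves alike on the two cores as far as this read-out can tell: the same change on two cores in this assay, a 1.1-fold higher number (0.04 log units; within the scatter) from compound 1 to compound 2 and a 1.7-fold lower number (0.22 log units; within the scatter) from compound 3 to compound 4, 1.8-fold (0.26 log units) apart, within the scatter of two such steps. Going by these compounds alone, this supports carrying the swap from one core to the other in this small set without expecting a clear shift in growth inhibition, but it rests on only two pairs of compounds, and it does not prove that the change has no effect at all or that the cores respond identically, since a small real difference could lie hidden in the scatter.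

Going by these compounds, both groups compared at this place are thiophene rings, so it remains open whether the same agreement between the cores would hold for a different kind of group there, such as an amine, a carboxylic acid or a longer alkyl chain. The ring atom that bears a group of 6 heavy atoms carries the same group in all four compounds, which leaves open how growth inhibition would respond if that group were replaced.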